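A few compounds are considered here, and "the series" means these few. Any claim that something is new, unique, unknown or untested is made for them only; others in the source may bear on it.

In a functional assay on HT-29 cells (Homo sapiens) for inhibition, read by MTT assay, with a stated time of 72 h (a lower number here means a stronger inhibitor, a higher number a weaker inhibitor), the three measured compounds of this set all sit at the weak end. Compound 1 `CCC(C)NC(=C\C(=O)/C=C/c1ccc(OC(C)=O)c(OC)c1)/C=C/c1ccc(OC(C)=O)c(OC)c1` gives > 25000 nM, which is a limit of the assay rather than a number. Compound 3 `CCC(C)NC(=C\C(=O)/C=C/c1ccc(O)cc1)/C=C/c1ccc(O)cc1`, which carries a sec-butyl on the amine nitrogen and phenol groups without methoxy, gives 13000 nM in this assay. Compound 2 `C=CCNC(=C\C(=O)/C=C/c1ccc(O)c(OC)c1)/C=C/c1ccc(O)c(OC)c1` gives > 25000 nM in this assay, again a limit and not a number. Compound 2 therefore stands at the limit of > 25000 nM in this assay, at which 2 of the 3 values shown sit, so only a floor of weakness is known for it, not a value.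

Compound 4 `COc1cc(/C=C/C(=O)/C=C(/C=C/c2ccc(O)c(OC)c2)NC2CCCCC2)ccc1O` is the not yet measured partner of compound 2. It differs in one place: cyclohexyl in place of allyl on an amine nitrogen.

Within the data shown here, no step between measured compounds is available to show what this kind of change does, and the two limits leave the position of compound 2 open. The expected step of an at least 1.2-fold lower number from compound 2 to compound 4 (0.09 log units; that floor lies within the scatter) is therefore none beyond the scatter, with a fair chance that this assay again reports only a limit. Compound 4 is expected to give 20000 nM in this assay, within a range from 7000 nM to 60000 nM.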

Compound 4, half-maximal inhibitory concentration: > 25000 nM
Compound 4 was reported as a limit (the forecaster's own chance of this, stated with the estimate: 50%); at least 1.2-fold (0.09 log units) between middle value and limit.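

Compound 4 gives > 25000 nM in this assay, a limit of the assay and not a number. Compound 2 also stands at a limit, so no step can be read from compound 2 to compound 4. The compounds shown leave open what cyclohexyl in place of allyl on an amine nitrogen does, with both compounds resting at one mark: the limit of > 25000 nM in this assay, at which 3 of the 4 values shown sit.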